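Series notes: hydrogen for chloro, compound 3 to compound 4

The source may hold more compounds than are shown below. What is called first, only, known or untested is meant among the compounds shown, and "the series" means these compounds.

Three amide-bearing analogues share one core. Compound 1 `Cc1ccc(NC(=O)CCCCc2cn(Cc3ccc4oc(-c5ccc(Cl)cc5)cc(=O)c4c3)nn2)cc1`, compound 2 `Cc1ccc(C(=O)NCc2cn(Cc3ccc4oc(-c5ccc(Cl)cc5)cc(=O)c4c3)nn2)cc1` and compound 3 `O=C(CCc1cn(Cc2ccc3oc(-c4ccc(Cl)cc4)cc(=O)c3c2)nn1)Nc1ccccc1` were measured in an assay on isolated protein for inhibition of Amine oxidase [flavin-containing] B (Homo sapiens), read by fluorescence and spectrophotometry; on this read-out lower numbers stand for stronger inhibition and higher numbers for weaker inhibition; compound 1 gives 32900 nM, compound 2 gives 32900 nM and compound 3 gives 32900 nM, so compound 3 stands level with both. The two measured steps, no change at the digits printed from compound 1 to compound 3 (within the scatter) and no change at the digits printed from compound 2 to compound 3 (within the scatter), both alter the amide side chain and leave the chloro-bearing ring untouched. Compound 4 `O=C(CCc1cn(Cc2ccc3oc(-c4ccccc4)cc(=O)c3c2)nn1)Nc1ccccc1` differs from compound 3 by hydrogen in place of chloro on an aromatic carbon. Within the data shown here, no measured step touches this ring, so the series gives no direct guide; what it does show is a flat response to changes elsewhere. Compound 4 is therefore expected to give 33000 nM, with a range of 11000 nM to 100000 nM. The expected step is a 1.0-fold higher number from compound 3 to compound 4 (0.00 log units; within the scatter), none beyond the scatter.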

Compound 4, half-maximal inhibitory concentration: 15600 nM
Compound 4: the middle estimate sits 2.1-fold (0.33 log units) above what was measured; the measured number falls inside the stated range.
By their numbers in this assay, from the lowest: compound 4; then compounds 1, 2 and 3 (each within the scatter of the next).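

Changing 4-chlorophenyl to phenyl gives a 2.1-fold lower number from compound 3 to compound 4 (0.32 log units; beyond the scatter), the only step shown that lies beyond the scatter, so this position responds where the amide side-chain changes did not. Chloro is therefore not needed here for the inhibition seen, and its loss leaves the number modestly lower. Nothing measured accounts for this step.

From the compounds shown here alone, whether fluoro, methyl or methoxy in the same place would move the number further remains open. So does whether the side chains of compound 1 and compound 2 would respond in the same way on a phenyl-bearing core.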